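Flipping the Linker Double Bond from E to Z

The source may hold more compounds than are shown below. What is called first, only, known or untested is meant among the compounds shown, and "the series" means these compounds.

Compound 3 `CCCCc1ccc(C#Cc2cn(C/C=C/CN3C(=O)c4ccccc4C3=O)c(=O)[nH]c2=O)cc1` gives 31000 nM in a functional assay on CCRF-CEM cells (Homo sapiens) for antiproliferative activity, read by MTT assay, with a stated time of 3 days (a higher number here means a weaker inhibitor, a lower number a stronger inhibitor), the lowest of the three numbers shown, though compound 1 `CCCCCCCCC#Cc1cn(C/C=C\CN2C(=O)c3ccccc3C2=O)c(=O)[nH]c1=O` with 39000 nM sits within the scatter of it, and compound 2 `O=C1c2ccccc2C(=O)N1C/C=C\Cn1cc(C#Cc2ccc(Br)cc2)c(=O)[nH]c1=O` gives 80000 nM. For the measured compounds named here, the one measured step, a 2.1-fold higher number from compound 1 to compound 2 (0.31 log units; beyond the scatter), concerns a different change and says nothing about geometry. Compound 4 `CCCCc1ccc(C#Cc2cn(C/C=C\CN3C(=O)c4ccccc4C3=O)c(=O)[nH]c2=O)cc1` differs from compound 3 in this way: the two compounds have the same atoms and bonds and differ only in configuration as drawn: 1 of 1 stereo elements differ; a double bond is drawn E in compound 3 and Z in compound 4. Going by the values given here, no measured step bears directly on such a change; compound 1 and compound 2 carry the Z form, compound 3 the E form, and their numbers lie close together. The expected step of a 1.1-fold higher number from compound 3 to compound 4 (0.05 log units; within the scatter) is therefore none beyond the scatter. Compound 4 is estimated at 35000 nM, within 12000 nM to 100000 nM.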

Compound 4, half-maximal inhibitory concentration: 23000 nM
Compound 4: the middle estimate sits 1.5-fold (0.18 log units) above what was measured; the measured number falls inside the stated range.
By their numbers in this assay, from the lowest: compounds 4, 3 and 1 (each within the scatter of the next); then compound 2.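

For the compounds shown here, the step of a 1.3-fold lower number from compound 3 to compound 4 (0.13 log units; within the scatter) is the first direct reading of the linker double bond, and it isolates one change: the fact that compounds 3 and 4 differ only in the configuration as drawn. This geometry change therefore stays within the scatter for this pair. With the Z form held, butyl in place of bromo on an aromatic carbon gives a 3.5-fold lower number from compound 2 to compound 4 (0.54 log units; beyond the scatter), a modest step beyond the scatter, while 4-butylphenyl in place of octyl gives a 1.7-fold lower number from compound 1 to compound 4 (0.23 log units; within the scatter), which stays within it.

From the compounds shown here alone, only compound 3 carries the E form, so whether geometry matters as little with other groups on the triple bond remains open. Also open, going by these compounds, is how an amine or a carboxylic acid in place of butyl would read.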